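A few compounds are considered here, and "the series" means these few. Any claim that something is new, unique, unknown or untested is made for them only; others in the source may bear on it.

Working notes on the dihydropyridine and cyclic urea amides

Compound 1 `COc1ccc(C2C(C(=O)Nc3ccc(Cl)cc3)=C(C)NC(C)=C2C(=O)Nc2ccc(Cl)cc2)cc1` and compound 2 `CC1=C(C(=O)Nc2ccc(Cl)cc2)C(c2ccco2)C(C(=O)Nc2ccc(Cl)cc2)=C(C)N1` share one core. In an ADME assay on Vero cells (Chlorocebus sabaeus) for cytotoxicity, read by sulforhodamine B assay, with a stated time of 3 days (on this read-out higher numbers stand for lower toxicity in this test and lower numbers for higher toxicity in this test), compound 1 gives 20 ug/mL, and compound 2 gives 24 ug/mL. The change between them is furan-2-yl in place of 4-methoxyphenyl on a saturated ring carbon, and it made a 1.2-fold higher number from compound 1 to compound 2 (0.08 log units; within the scatter), so nothing can be read into the order of these two values.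

Compound 3 `COc1ccc(NC(=O)C2=C(C)NC(=O)NC2c2ccc(OC)cc2)cc1` carries a different core; how the core of compound 3 differs from the core of compound 1 is not broken down here. In this assay compound 3 gives 158 ug/mL, the highest of the three numbers and beyond the scatter from both compound 1 and compound 2.

Compound 4 `COc1ccc(NC(=O)C2=C(C)NC(=O)NC2c2ccco2)cc1` is the unmeasured member. It differs from compound 3 by furan-2-yl in place of 4-methoxyphenyl on a saturated ring carbon. For the measured compounds named here, this is the same kind of change as the one from compound 1 to compound 2, not the same: there the saturated ring carbon sat in a six-membered non-aromatic ring with 1 nitrogen, next to two ring atoms that each bear a (4-chlorophenyl)carbamoyl group, two ring bonds from two ring atoms that each bear a methyl group; here it sits in a six-membered non-aromatic ring with 2 nitrogen, next to the ring nitrogen, next to the ring atom that bears a large group, two ring bonds from the ring atom that bears a methyl group.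

From compound 3 to compound 4 in this assay a step of a 1.1-fold higher number from compound 3 to compound 4 (0.03 log units; within the scatter) is expected, because the same kind of change gave a 1.2-fold higher number from compound 1 to compound 2 (0.08 log units; within the scatter) and that step lay within the scatter. With one precedent only, on another core, the expectation is loose. Compound 4 is therefore estimated at 170 ug/mL in this assay, with a range from 70 ug/mL to 400 ug/mL.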

Compound 4, half-maximal cytotoxic concentration: 210 ug/mL
Compound 4: the middle estimate sits 1.2-fold (0.09 log units) below what was measured; low and high end bracket the measured number.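

In this assay, furan-2-yl in place of 4-methoxyphenyl on the saturated ring carbon of the core of compound 3 gave a 1.3-fold higher number from compound 3 to compound 4 (0.12 log units; within the scatter), a step too small to count as a change in either direction. Set beside the earlier step, this one does not differ from it, and the swap carries over from one core to the other as a step that stays within the scatter on both: the same change on two cores in this assay, a 1.2-fold higher number (0.08 log units; within the scatter) from compound 1 to compound 2 and a 1.3-fold higher number (0.12 log units; within the scatter) from compound 3 to compound 4, 1.1-fold (0.04 log units) apart, within the scatter of two such steps This is agreement between two pairs only, and both steps are close to nil, so it shows that the swap left the number in place on these two cores but not that it would do so on a third core, nor anything about why the number holds.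

Still open is how the number responds when a group of another kind sits on that saturated ring carbon, such as a carboxylic acid or a longer chain ending in an amine, as the pairs shown span only 4-methoxyphenyl and furan-2-yl there. Also open, going by these compounds, is how far the amide group and the core each count on their own: the (4-chlorophenyl)carbamoyl groups occur only on the core of compound 1, and the 4-methoxyphenyl amide only on the core of compound 3.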